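The source may report more compounds than this note shows. Statements on the series, on what has been measured and on what is new or still open speak of the compounds shown alone.

In a functional assay on ECV-304 cells (Homo sapiens) for cytotoxicity, read by MTT assay, with stated times of 24 h and 12 h (on this read-out lower numbers stand for an effect already at smaller amounts and higher numbers for an effect only at larger amounts of compound), compound 1 `CCOC(=O)/C=C/c1ccc(OCc2nc(C)c(C)nc2C)cc1` gives 206000 nM and compound 2 `CCOC(=O)/C=C/c1cc(OC)c(OCc2nc(C)c(C)nc2C)c(OC)c1` gives 2310000 nM. Compound 2 therefore holds the higher of the two numbers, and its gap to compound 1 lies beyond the usual scatter. On this read-out, compound 2 shows its effect only at the larger amount.

Compound 3 `COc1cc(/C=C/C(=O)O)cc(OC)c1OCc1nc(C)c(C)nc1C` keeps everything in compound 2 except one small part: hydrogen in place of ethyl on an oxygen next to a carbonyl group. Hydrogen stands in place of ethyl on an oxygen next to a carbonyl group, so the ethoxycarbonyl becomes a carboxy.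

Among the measured compounds shown here, no pair of measured compounds shows this same change, so the data offer no direct guide to its size or direction. The two measured values show only that this read-out can differ clearly within the series, which argues for a wide range. The expected outcome is no change beyond the scatter, with a slight lean towards a lower number, and the estimated step is a 1.5-fold lower number from compound 2 to compound 3 (0.19 log units; within the scatter). For compound 3 the expected value is 1500000 nM, with an estimated range from 200000 nM to 8000000 nM.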

Compound 3, half-maximal effective concentration: 3530000 nM
The estimate for compound 3 lay 2.4-fold (0.37 log units) below the measured number; the range from low to high includes it.
By their numbers in this assay, from the lowest: compound 1; then compounds 2 and 3 (each within the scatter of the next).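

In this assay hydrogen in place of ethyl on an oxygen next to a carbonyl group, which turns the ethoxycarbonyl into a carboxy, gives a 1.5-fold higher number from compound 2 to compound 3 (0.18 log units; within the scatter) and so leaves the two compounds indistinguishable on this read-out. Among the compounds shown here, this is the first step with a change in only one place, and it shows that, with the rest of compound 2 held fixed, the ethyl can be removed here without a change that stands out from the usual variation between repeated measurements. The data shown offer no explanation for this outcome.

As far as these compounds go, one pair cannot show whether this holds across the series: compound 1 carries the same ethoxycarbonyl, and how its number would respond to the same swap remains open. From the compounds shown here alone, it also remains open whether a methyl or a longer chain on this oxygen, or an amide in place of the ester, would likewise stay within the usual variation or would move the number clearly in either direction.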